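The source may hold more compounds than are shown below. What is called first, only, known or untested is meant among the compounds shown, and "the series" means these compounds.

Measured in a functional assay on HCT-116 cells (Homo sapiens) for inhibition, read by MTT assay, with a stated time of 72 h; a higher number here means a weaker inhibitor, a lower number a stronger inhibitor:
- compound 1 `CC(C)CCN(CCCCCCC(=O)NO)c1ncc(C(=O)NCc2cccnc2)s1`: 12000 nM
- compound 2 `O=C(NO)c1ccc(CN(Cc2ccc(F)cc2)c2ncc(C(=O)NCCCn3ccnc3)s2)cc1`: 99000 nM
- compound 3 `O=C(CCCCCCN(Cc1ccc(F)cc1)c1ncc(C(=O)NCCCn2ccnc2)s1)NO`: 9700 nM

Compound 3 at 9700 nM and compound 1 at 12000 nM lie within the scatter of each other, and compound 2 at 99000 nM stands well apart from that pair.

The next compound is compound 4 `O=C(CCCCCCN(Cc1ccc(F)cc1)c1ncc(C(=O)NCc2cccnc2)s1)NO`, which keeps everything in compound 3 except the group on the amide side: pyridin-3-yl in place of 2-(1H-imidazol-1-yl)ethyl on a saturated chain carbon bound to an amide-type nitrogen. Read one bond further out, ((pyridin-3-yl)methyl)carbamoyl takes the place of (3-(1H-imidazol-1-yl)propyl)carbamoyl.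

For the measured compounds named here, no measured step touches this place. Going by the values given here, the one step available, a 10-fold lower number from compound 2 to compound 3 (1.01 log units; beyond the scatter), is large but concerns the 5-(hydroxycarbamoyl)pentyl group, which compound 4 retains, so it sets no size for the present change. Among the compounds with values here, the only indirect evidence is compound 1, which already carries the entering group and gives 12000 nM, within the scatter of compound 3, although it also differs from compound 3 elsewhere. On that thin basis, no step beyond the scatter is expected in this assay.

The expected change is a 1.1-fold lower number from compound 3 to compound 4 (0.03 log units; within the scatter), with neither direction favoured by the data.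

For compound 4 the estimated value is 9000 nM, with an expected range from 3500 nM to 23000 nM.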

Compound 4, half-maximal inhibitory concentration: 17000 nM
Estimate against measurement, compound 4: 1.9-fold (0.28 log units) below, and the stated range covers the measured number.
By their numbers in this assay, from the lowest: compounds 3, 1 and 4 (each within the scatter of the next); then compound 2.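

In this assay, the amide-side group now has its first direct reading, a 1.8-fold higher number from compound 3 to compound 4 (0.24 log units; within the scatter), with the 5-(hydroxycarbamoyl)pentyl and 4-fluorophenyl groups held constant. Within this comparison, ((pyridin-3-yl)methyl)carbamoyl and (3-(1H-imidazol-1-yl)propyl)carbamoyl are not separated, although the one brings a six-membered aromatic ring and the other a five-membered aromatic ring with 2 hetero atoms. For the compounds shown here, the second new reading, a 1.4-fold higher number from compound 1 to compound 4 (0.15 log units; within the scatter), shows that 4-fluorophenyl in place of isobutyl on a saturated chain carbon bound to a nitrogen on an aromatic ring is likewise not separated, leaving a 10-fold lower number from compound 2 to compound 3 (1.01 log units; beyond the scatter) as the only step beyond the scatter among those that can be read.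

Still open, as far as these compounds go, is whether an amide side ending in a morpholine or a dimethylamino group, rather than either aromatic ring, would stay within the same scatter. Also open, from the compounds shown here alone, is how a hydroxamic acid chain longer than 5-(hydroxycarbamoyl)pentyl would read in this assay.

Nothing available beyond these cell numbers bears on this result.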